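Acetoxy on the prenyl chain of a hydroxyquinone

A few compounds are considered here, and "the series" means these few. Any claim that something is new, unique, unknown or untested is made for them only; others in the source may bear on it.

The shared core of compound 1 `COc1ccc(O)c2c1C(=O)C=C(CCC=C(C)C)C2=O` carries a prenyl chain on its quinone ring. In a functional assay on MDA-MB-231 cells (Homo sapiens) for cytotoxicity, read by MTT assay, with a stated time of 48 h (on this read-out higher numbers stand for weaker inhibition and lower numbers for stronger inhibition), compound 1 gives 1190 nM, the lowest of the two numbers at hand; its regioisomer compound 2 `COc1ccc(O)c2c1C(=O)C(CCC=C(C)C)=CC2=O` gives 5110 nM, a gap that lies beyond the scatter. Compound 3 `COc1ccc(O)c2c1C(=O)C=C([C@H](CC=C(C)C)OC(C)=O)C2=O` differs from compound 1 by acetoxy in place of hydrogen on a saturated chain carbon bound to a double-bonded ring carbon and a saturated chain carbon. Going by the values given here, no measured pair shows this kind of change, so the step from compound 1 to compound 3 is expected to be small, a 1.3-fold higher number from compound 1 to compound 3 (0.10 log units; within the scatter), within the scatter in either direction. Compound 3 is therefore estimated at 1500 nM, with a range from 500 nM to 5000 nM.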

Compound 3, half-maximal inhibitory concentration: 90 nM
Compound 3: middle estimate off by 17-fold (1.22 log units), on the high side, and the stated range ends above it.
By their numbers in this assay, from the lowest: compound 3; then compound 1; then compound 2.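

In this assay, the earlier pair spoke only to where the prenyl chain sits on the ring, whereas this result shows that the chain itself is a sensitive place. Acetoxy in place of hydrogen on this saturated chain carbon gives a 13-fold lower number from compound 1 to compound 3 (1.12 log units; beyond the scatter) and so makes compound 3 the lowest of the three numbers. Nothing at hand accounts for the size of this step. On these data alone, whether a hydroxyl or an amine at this carbon would give a similar number stays open, as does whether acetoxy would act alike on the chain of compound 2.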